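Moving the tetrazole off the ring by one carbon in compound 3

The source may hold more compounds than are shown below. What is called first, only, known or untested is meant among the compounds shown, and "the series" means these compounds.

Compound 1, `CCCc1c(COc2ccc(-c3nn[nH]n3)cc2)ccc(C=O)c1O`, in a functional assay on ileum (Cavia porcellus) for inhibition of cysteinyl leukotriene receptor (Homo sapiens); a lower number here means a stronger inhibitor, a higher number a weaker inhibitor: 398 nM
Compound 2, `CCc1c(COc2ccc(Cc3nnn[nH]3)cc2)ccc(C(C)=O)c1O`, in this assay: 12.6 nM
Compound 3, `CCCc1c(COc2ccc(-c3nn[nH]n3)cc2)ccc(C(C)=O)c1O`, in this assay: 10 nM

Among these three, compound 3 gives the lowest number, although compound 2 sits within the scatter of it, so no order between the two can be claimed; compound 1 is the only one clearly apart, as the step of a 40-fold lower number from compound 1 to compound 3 (1.60 log units; beyond the scatter) shows. Compound 4, `CCCc1c(COc2ccc(Cc3nnn[nH]3)cc2)ccc(C(C)=O)c1O`, differs from compound 3 in one place: (1H-tetrazol-5-yl)methyl in place of 2H-tetrazol-5-yl on an aromatic carbon. Going by the values given here, the single measured step, a 40-fold lower number from compound 1 to compound 3 (1.60 log units; beyond the scatter), concerns the carbonyl and not this change, so it gives no guide here. What remains is that compound 2 already carries the methylene-linked tetrazole and gives 12.6 nM, a value within the scatter of compound 3, though compound 2 also differs in its alkyl chain. The expectation is therefore no step beyond the scatter. Compound 4 is estimated at 12 nM, with a range of 5 nM to 30 nM, which means an expected step of a 1.2-fold higher number from compound 3 to compound 4 (0.08 log units; within the scatter).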

Compound 4, half-maximal inhibitory concentration: 10 nM
Beside the measured number, compound 4's estimate is 1.2-fold (0.08 log units) above it; measured number inside the range.
By their numbers in this assay, from the lowest: compounds 3, 4 and 2 (each within the scatter of the next); then compound 1.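

In this assay the (1H-tetrazol-5-yl)methyl in place of 2H-tetrazol-5-yl gives no change at the digits printed from compound 3 to compound 4 (within the scatter) and so, at this place on the aromatic ring, para to a large group, the two tetrazole groups cannot be told apart. The methyl added to the saturated chain gives a 1.3-fold lower number from compound 2 to compound 4 (0.10 log units; within the scatter) and so, with the (1H-tetrazol-5-yl)methyl group held constant, this chain difference is also not resolved. Nothing available accounts for either result.

The compounds shown leave open whether a carboxylic acid in place of the tetrazole, or a two-carbon link to it, would stay within the scatter of these values. They also leave open whether a butyl chain, or an aldehyde carbonyl alongside the (1H-tetrazol-5-yl)methyl group, would separate from them.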